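Oxadiazole addition on a pyrimidine amide: expected potency gain

The source may hold more compounds than are shown below. What is called first, only, known or untested is meant among the compounds shown, and "the series" means these compounds.

Measured compounds:
compound 1, `O=C(NCc1ccccc1)c1ccc(-c2ccccc2)nc1`, gives 122 nM in an assay on isolated protein for inhibition of Hematopoietic prostaglandin D synthase (Homo sapiens), read by fluorescence polarization; a lower number here means a stronger inhibitor, a higher number a weaker inhibitor;
compound 2, `O=C(NCc1ccccc1)c1cnc(-c2ccccc2)nc1`, gives 11.7 nM in this assay;
compound 3, `CC(C)(O)c1nc(-c2cccc(CNC(=O)c3ccc(-c4ccccc4)nc3)c2)no1`, gives 27.7 nM in this assay.

Compound 1 and compound 3 share a core; compound 3 carries the addition (5-(1-hydroxy-1-methylethyl)-1,2,4-oxadiazol-3-yl in place of hydrogen on an aromatic carbon). That addition produced the step of a 4.4-fold lower number from compound 1 to compound 3 (0.64 log units; beyond the scatter). Compound 2 has a different core from compound 1, and the difference between the two cores is not broken down here; what is visible is that compound 2 gives the lowest number of the three, with compound 3 closest to it and compound 1 furthest.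

Compound 4, `CC(C)(O)c1nc(-c2cccc(CNC(=O)c3cnc(-c4ccccc4)nc3)c2)no1`, is not yet measured. It differs from compound 2 by 5-(1-hydroxy-1-methylethyl)-1,2,4-oxadiazol-3-yl in place of hydrogen on an aromatic carbon, and since the place described for this change matches the place described for compound 1 to compound 3 word for word, it is the same change, appearing in two pairs among the compounds shown.

In this assay the step from compound 2 to compound 4 is expected to be a 3.3-fold lower number from compound 2 to compound 4 (0.52 log units; beyond the scatter), somewhat smaller than the earlier one, because a 4.4-fold lower number from compound 1 to compound 3 (0.64 log units; beyond the scatter) was seen on a weaker starting point and compound 2 already sits at a low number. On that basis, compound 4 is estimated at 3.5 nM, with a range from 1.2 nM to 10 nM expected.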

Compound 4, half-maximal inhibitory concentration: 7.18 nM
The estimate for compound 4 lay 2.1-fold (0.31 log units) below the measured number; low and high end bracket the measured number.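

In this assay, the addition of 5-(1-hydroxy-1-methylethyl)-1,2,4-oxadiazol-3-yl did not carry over at the same size from one core to the other, and the two steps differ: the same change on two cores in this assay, a 4.4-fold lower number (0.64 log units; beyond the scatter) from compound 1 to compound 3 and a 1.6-fold lower number (0.21 log units; within the scatter) from compound 2 to compound 4, 2.7-fold (0.43 log units) apart, beyond the scatter of two such steps. On the core of compound 2, the step is a 1.6-fold lower number from compound 2 to compound 4 (0.21 log units; within the scatter), so the two compounds cannot be told apart in this assay, whereas the same addition on the core of compound 1 gave a step beyond the scatter. Among the compounds shown here, this shows that the size of the step depends on the context in this pair of cores, but with only two pairs it does not show why, and it cannot separate the difference between the cores from the difference in the starting values, since the core of compound 2 is also the one that starts at the lower number.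

Going by these compounds, it remains open whether another group in the same place, such as a carboxylic acid or an amine, would also give steps that differ between these two cores. On these data alone, it also remains open whether a third core would give a step nearer to the one seen on the core of compound 1 or to the one seen on the core of compound 2.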